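This account rests on a few compounds, and the source may have more. Where it says the series, first, only, none or still open, it means among the compounds named here.

Notes on the series. Within the data shown here, in a physicochemical assay for lipophilicity, read by HPLC, with a stated time of 90 min, tested at 100 uM (a higher number here means a more lipophilic compound, a lower number a more polar compound), compound 1 `O=C(Nc1ccc(OC(F)(F)F)cc1)NC1CCN(C(=O)C2CCCOC2)CC1` gives 3.42, the lowest of the three numbers so far. Compound 2 `CC(C)C(=O)N1CCC(NC(=O)Nc2ccc(OC(F)(F)F)c(F)c2)CC1` gives 4.73 in this assay, and compound 3 `CCOC(=O)N1CCC(NC(=O)Nc2ccc(C(F)(F)F)c(F)c2)CC1` gives 5.46; both stand beyond the scatter above compound 1, compound 2 the nearer and compound 3 the further. Among the measured compounds shown here, no pair of the measured compounds differs in a single place, so no single-change step has been measured within the set. Compound 4 `O=C(Nc1ccc(OC(F)(F)F)cc1)NC1CCN(C(=O)[C@@H]2CCOC2)CC1` is the next candidate for this assay. Its change from compound 1 is oxolan-3-yl in place of oxan-3-yl on a carbonyl carbon, the rest of the structure of compound 1 being kept. The expectation for this assay is a modest drop, close to the edge of the scatter, and not a shift of the size seen between the measured compounds. The expected step is a number 0.37 log units lower from compound 1 to compound 4 (beyond the scatter). Compound 4 is expected to give 3.05 in this assay, within a range from 2.6 to 3.45.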

Compound 4, partition coefficient: 3.38
The estimate for compound 4 lay 0.33 log units below the measured number; low and high end bracket the measured number.
By their numbers in this assay, from the lowest: compounds 4 and 1 (each within the scatter of the next); then compound 2; then compound 3.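

Among these compounds, at the carbonyl carbon on the amide-type nitrogen in a ring, oxolan-3-yl in place of oxan-3-yl gives a number 0.04 log units lower from compound 1 to compound 4 (within the scatter) in this assay, the first single-change step. Compound 1 and compound 4 therefore cannot be told apart in this read-out, so going from the six-membered to the five-membered non-aromatic ring, with its one oxygen kept as the hetero atom, leaves the number within the scatter. Nothing at hand bears on why the two rings read alike.

On these data alone, the step covers only these two cyclic ether groups, so it remains open how an open-chain ether, an amine or a carboxylic acid on the same carbonyl carbon would read. Also open, as far as these compounds go, is how the opposite configuration of the defined stereocentre in compound 4 would read in this assay at this position.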